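The compounds below may be only part of what the source reports. "The series", "measured", "known", "first", "only" and "open" are said of these compounds alone.

For the measured compounds named here, compound 1 `CC(C)C(/C=C1\NC(=O)NC1=O)c1ccc(-c2ccc3cccc(F)c3c2)[nH]c1=O` is the weakest binder among the three measured members of this set. In an assay on membranes from Chem-1 cells for displacement of a labelled ligand from prostaglandin E2 receptor EP3 subtype (Homo sapiens), read by scintillation counting, with a stated time of 2 h (a higher number here means a weaker inhibitor, a lower number a stronger inhibitor), compound 1 gives 43 nM. Compound 3 `CC(C)[C@@H](c1ccc(-c2ccc3cccc(F)c3c2)[nH]c1=O)[C@H]1OC(=O)NC1=O` gives 27 nM in this assay, which falls within the scatter of the figure for compound 1. Compound 2 `CCC(CC)C(/C=C1\OC(=O)NC1=O)c1ccc(-c2ccc3cccc(F)c3c2)[nH]c1=O` gives 13 nM in this assay, a figure that lies beyond the scatter relative to compound 1, so among the measured compounds only the gap between compound 1 and compound 2 counts as a real difference.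

Compound 4 `CC(C)C(/C=C1/C(=O)NC(=O)N1C)c1ccc(-c2ccc3cccc(F)c3c2)[nH]c1=O` has not been measured. It differs from compound 1 by methyl in place of hydrogen on an amide-type nitrogen in a ring. Going by the values given here, no pair of measured compounds isolates this single change, so the numbers for compounds 2 and 3 give no direct guide to it. On that basis no step beyond the scatter is expected, and the change a 1.0-fold higher number from compound 1 to compound 4 (0.02 log units; within the scatter) is estimated to be small. Compound 4 is expected to give about 45 nM in this assay, with a plausible range from 12 nM to 160 nM.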

Compound 4, inhibition constant: 6 nM
Estimate against measurement, compound 4: 7.5-fold (0.88 log units) above; the measured number lies below the stated range.
By their numbers in this assay, from the lowest: compound 4; then compound 2; then compounds 3 and 1 (each within the scatter of the next).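

In this assay, methyl in place of hydrogen on an amide-type nitrogen in a ring gives a 7.2-fold lower number from compound 1 to compound 4 (0.86 log units; beyond the scatter) and so goes beyond the scatter. For the compounds shown here, this is the first single-place change in the set that can be read, and it shows that this position of the five-membered non-aromatic ring accepts a methyl group with a gain in binding, so the hydrogen on this nitrogen is not needed to reach the level of compound 1. No measurement shown here accounts for the size of this gain.

On these data alone, whether ethyl or a longer chain on this nitrogen would keep the gain remains open, as does the effect of methyl on the other ring nitrogen. A single pair also cannot tell whether the same change would carry over to compounds with a different ring, such as compound 2 or compound 3.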